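Naphthalen-2-yl for Phenyl on the Hydroxyl-Bearing Chain

A few compounds are considered here, and "the series" means these few. Any claim that something is new, unique, unknown or untested is made for them only; others in the source may bear on it.

Compound 1: `O=C(O)CCCCCCN1C(=O)CC[C@@H]1CCC(O)Cc1ccccc1`. In an assay on HEK293 cells for binding affinity to prostaglandin E2 receptor EP2 subtype (Rattus norvegicus) (a higher number here means a weaker inhibitor, a lower number a stronger inhibitor), compound 1 gives > 3200 nM, which is a limit of the assay.
Compound 2: `O=C(O)c1ccc(CCCN2C(=O)CC[C@@H]2CCC(O)Cc2ccccc2)s1`. In this assay compound 2 gives 690 nM.

Compound 2 holds the only number shown; the other value is a limit, (the limit of > 3200 nM in this assay, at which 1 of the 2 values shown sits). For the measured compounds named here, the single measured step, an at least 4.6-fold lower number from compound 1 to compound 2 (0.66 log units; beyond the scatter), lies at the other end of the molecule from where compound 3, `O=C(O)c1ccc(CCCN2C(=O)CC[C@@H]2CCC(O)Cc2ccc3ccccc3c2)s1`, differs: naphthalen-2-yl in place of phenyl on a saturated chain carbon, two bonds along the chain from an oxygen on a saturated carbon. Going by the values given here, no measured step bears on this change, so no direction can be drawn from the data. Compound 3 is therefore expected to stay close to compound 2, with a 1.1-fold lower number from compound 2 to compound 3 (0.03 log units; within the scatter). The estimate for compound 3 is 650 nM, spanning 150 nM to 2800 nM.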

Compound 3, half-maximal inhibitory concentration: > 3200 nM
Compound 3 was reported as a limit (the forecaster's own chance of this, stated with the estimate: 15%); at least 4.9-fold (0.69 log units) between middle value and limit.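

At this position, two bonds along the chain from an oxygen on a saturated carbon, the change gives an at least 4.6-fold higher number from compound 2 to compound 3 (0.66 log units; beyond the scatter) in this assay, so this end of the molecule does respond to the aryl group, and enlarging phenyl to naphthalen-2-yl loses binding. On these data alone, compound 3 is reported only as a limit of the assay, so the full size of this step stays unknown: the limit of > 3200 nM in this assay, at which 2 of the 3 values shown sit.

The compounds shown leave open how naphthalen-1-yl, a phenyl ring carrying a fluorine, or a phenoxy group would compare with phenyl here.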